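From 2-(Trifluoromethyl)phenyl to 2,6-Difluorophenyl on the Ketone

The source may report more compounds than this note shows. Statements on the series, on what has been measured and on what is new or still open speak of the compounds shown alone.

Of the compounds shown here, two sharing one core have been measured in a functional assay (aorta) with Rattus norvegicus as the target; a lower number here means a less potent compound, a higher number a more potent compound, by a factor of ten per unit of this negative logarithm. Compound 1 `Cc1ccccc1C(=O)c1ccc2c(c1)C(n1ccccc1=O)=CC(C)(C)O2` gives 6.83 in this assay, and compound 2 `CC1(C)C=C(n2ccccc2=O)c2cc(C(=O)c3ccccc3C(F)(F)F)ccc2O1` gives 6.76. For the measured compounds named here, the one measured step, a number 0.07 log units lower from compound 1 to compound 2 (within the scatter), lies within the scatter. Compound 2 thus holds the lower of the two numbers, but its distance from compound 1 is within the scatter, so the two cannot be ranked.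

Compound 3 `CC1(C)C=C(n2ccccc2=O)c2cc(C(=O)c3c(F)cccc3F)ccc2O1` has not yet been measured. It differs from compound 2 in one place: 2,6-difluorophenyl in place of 2-(trifluoromethyl)phenyl on a carbonyl carbon. Going by the values given here, no measured step covers this exact exchange; the nearest guide is a number 0.07 log units lower from compound 1 to compound 2 (within the scatter), which shows that an earlier change within the aryl group on the carbonyl carbon left the number within the scatter. On that basis no step beyond the scatter is expected, a number 0.04 log units higher from compound 2 to compound 3 (within the scatter). Compound 3 is therefore estimated at 6.8, within a range from 6.3 to 7.3.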

Compound 3, logarithm of the reciprocal of the active concentration, log(1/C): 6.97
Compound 3: the middle estimate sits 0.17 log units below what was measured, and the stated range covers the measured number.
By their numbers in this assay, from the lowest: compounds 2, 1 and 3 (each within the scatter of the next).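

In this assay, the step to 2,6-difluorophenyl on the carbonyl carbon is a number 0.21 log units higher from compound 2 to compound 3 (within the scatter), and the comparison with the 2-methylphenyl of compound 1 is a number 0.14 log units higher from compound 1 to compound 3 (within the scatter), so neither exchange separates the compounds. The earlier pair covered only 2-methylphenyl and 2-(trifluoromethyl)phenyl, whereas compound 3 extends this position to a ring carrying two fluorines, and all three compounds now stand within the scatter of one another. Nothing available bears on why these numbers stay so close.

The compounds shown leave open whether any exchange at this position can move the number beyond the scatter. They also do not tell whether an aromatic ring is needed here at all, or how a cyclohexyl group, or a phenyl ring carrying an amine or a carboxylic acid, would read.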